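A Second Fluorine on the Benzyl Group

This account rests on a few compounds, and the source may have more. Where it says the series, first, only, none or still open, it means among the compounds named here.

Compound 1 `C=C1C(=O)O[C@H]2[C@H]1CC/C(COC(=O)CCC(=O)OCn1cc(F)c(=O)[nH]c1=O)=C\CC[C@@]1(C)O[C@@H]21` and compound 2 `C=C1C(=O)O[C@H]2[C@H]1CC/C(COC(=O)Cn1cc(F)c(=O)n(Cc3ccc(F)cc3)c1=O)=C\CC[C@@]1(C)O[C@@H]21` share the same core and differ only in the group joined to it. In a functional assay on Bel7402/5-FU cells (Homo sapiens) for antiproliferative activity, read by MTT assay, with a stated time of 72 h (a higher number here means a weaker inhibitor, a lower number a stronger inhibitor), compound 1 reaches only a limit of the assay, > 20000 nM, and so gives no number; this is recorded as the limit of > 20000 nM in this assay, at which 1 of the 2 values shown sits. Within the data shown here, compound 2 gives 1140 nM in this assay, the only true number among the two values shown, so it stands alone as the single measured point of reference.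

Compound 3 `C=C1C(=O)O[C@H]2[C@H]1CC/C(COC(=O)Cn1cc(F)c(=O)n(Cc3cc(F)ccc3F)c1=O)=C\CC[C@@]1(C)O[C@@H]21` differs from compound 2 by 2,5-difluorophenyl in place of 4-fluorophenyl on a saturated chain carbon bound to an aromatic nitrogen. Among the measured compounds shown here, no measured pair shows the effect of this kind of change, so there is nothing to point to either way. In this assay a step of a 1.1-fold higher number from compound 2 to compound 3 (0.02 log units; within the scatter) is expected, which lies within the usual scatter rather than beyond it. Compound 3 is therefore estimated at 1200 nM, with a range from 500 nM to 3000 nM.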

Compound 3, half-maximal inhibitory concentration: 4610 nM
Beside the measured number, compound 3's estimate is 3.8-fold (0.58 log units) below it, and the stated range ends below it.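

In this assay, replacing 4-fluorobenzyl with 2,5-difluorobenzyl gives a 4.0-fold higher number from compound 2 to compound 3 (0.61 log units; beyond the scatter), the first step measured at this place on the molecule. It shows that the fluorine pattern on this ring matters: the swap adds one fluorine and changes where the fluorines sit, and the compound becomes a weaker inhibitor rather than holding steady. Nothing measured here explains this loss.

With both fluorine changes made in a single step, the compounds shown cannot tell whether the added fluorine or the absence of fluorine from the original spot drives the result. Also open, going by these compounds, is how an unsubstituted benzyl, a 2-fluorobenzyl or a 4-methoxybenzyl group would compare at this place, and each would help separate those two effects.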